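Two measured ureas, and a piperazine analogue awaiting test

The compounds below may be only part of what the source reports. "The series", "measured", "known", "first", "only" and "open" are said of these compounds alone.

The account covers two compounds with a shared core bearing a (1H-indol-3-yl)sulfanyl group and a urea. Compound 1 `O=C(Nc1ccccc1)Nc1nc(NC2CC2)cc(Sc2c[nH]c3ccccc23)n1` carries a cyclopropylamino group; in a functional assay on MDA-MB-231 cells (Homo sapiens) for inhibition, with a stated time of 72 h (on this read-out higher numbers stand for weaker inhibition and lower numbers for stronger inhibition), compound 1 gives 7860 nM. Compound 2 `Cc1cc(Cl)ccc1NC(=O)Nc1nc(Nc2ccccc2)cc(Sc2c[nH]c3ccccc23)n1` carries an anilino group and a 4-chloro-2-methylphenyl urea; in this assay compound 2 gives 17100 nM. Of these two numbers compound 1 holds the lower one, and the gap to compound 2 lies beyond the scatter. Compound 3 `O=C(Nc1ccccc1)Nc1nc(Sc2c[nH]c3ccccc23)cc(N2CCN(c3ccccn3)CC2)n1` differs from compound 1 by 4-(pyridin-2-yl)piperazin-1-yl in place of cyclopropylamino on an aromatic carbon. Among the measured compounds shown here, no measured pair isolates this change, so its effect is not known from the data. A step of modest size in this assay, not clearly beyond the scatter and if anything toward weaker inhibition, is expected, as a 1.4-fold higher number from compound 1 to compound 3 (0.15 log units; within the scatter). Compound 3 is accordingly estimated at 11000 nM, with a range from 3500 nM to 35000 nM.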

Compound 3, half-maximal inhibitory concentration: 19500 nM
Compound 3: middle estimate off by 1.8-fold (0.25 log units), on the low side; the measured number falls inside the stated range.
By their numbers in this assay, from the lowest: compound 1; then compounds 2 and 3 (each within the scatter of the next).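

In this assay, placing 4-(pyridin-2-yl)piperazin-1-yl instead of cyclopropylamino on this aromatic carbon gives a 2.5-fold higher number from compound 1 to compound 3 (0.39 log units; beyond the scatter), which shows that this position responds to the change, toward weaker inhibition. The entering group has 12 heavy atoms against 4 and 0 hydrogen-bond donors against 1, yet the step remains modest in size, so this position accepts a much larger group with only a modest change in the read-out. No evidence is available on what lies behind this step.

This single pair cannot separate the contribution of the piperazine ring from that of the pyridine ring, nor the larger size of the group from the lost hydrogen-bond donor. From the compounds shown here alone, what an unsubstituted piperazin-1-yl, a morpholin-4-yl or a simple dimethylamino group would give on this carbon remains open.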